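The source may hold more compounds than are shown below. What is called first, only, known or untested is meant among the compounds shown, and "the series" means these compounds.

Working notes on the series. Compound 1 `CSC(=O)C#CC(C)(C)N(C)c1ccccc1` and compound 2 `CSC(=O)C#CC(C)(C)N(C)Cc1ccccc1` share the same core and differ at the amine nitrogen. In a functional assay on DU-145 cells (Homo sapiens) for inhibition, with a stated time of 3 days (a higher number here means a weaker inhibitor, a lower number a stronger inhibitor), compound 1 gives 12500 nM. In this assay compound 2 gives 1400 nM, the lower of the two numbers, and that gap lies beyond the scatter. Compound 3 `CSC(=O)C#CC(C)(C)N(Cc1ccccc1)Cc1ccccc1` is not yet measured; it carries phenyl in place of hydrogen on a saturated chain carbon bound to an amine nitrogen, which read one bond further out is methyl to benzyl. Among the compounds with values here, with only two numbers as a guide, the step from compound 2 to compound 3 is expected to be small, a 1.4-fold higher number from compound 2 to compound 3 (0.15 log units; within the scatter), with no clear direction beyond the scatter. Compound 3 is therefore estimated at 2000 nM in this assay, within a range of 500 nM to 8000 nM.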

Compound 3, half-maximal inhibitory concentration: 7000 nM
The estimate for compound 3 lay 3.5-fold (0.54 log units) below the measured number; the measured number falls inside the stated range.
By their numbers in this assay, from the lowest: compound 2; then compounds 3 and 1 (each within the scatter of the next).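

At the amine nitrogen, the methyl to benzyl change costs inhibition in this assay: a 5.0-fold higher number from compound 2 to compound 3 (0.70 log units; beyond the scatter), a modest step but beyond the scatter. Phenyl in place of hydrogen on a saturated chain carbon bound to an amine nitrogen is therefore not a neutral change, and within this pair the methyl of compound 2 gives the lower number. Open, on these data alone, is how an ethyl group, a longer chain or a plain hydrogen on the amine nitrogen would compare with that methyl. No measurement shown speaks to the reason for this step.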